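A Methyl Added to the Benzyl Group of Compound 3

The compounds below may be only part of what the source reports. "The series", "measured", "known", "first", "only" and "open" are said of these compounds alone.

In a functional assay on A2780 cells (Homo sapiens) for cytotoxicity, read by MTT assay, with a stated time of 72 h (a lower number here means a stronger inhibitor, a higher number a weaker inhibitor), compound 1 `Cc1cc(C)cc(C(=O)N(CCCCCC(=O)Nc2ccccc2N)CC(=O)NC2CCCCC2)c1` gives 42000 nM while compound 2 `Nc1ccccc1NC(=O)CCCCCN(CC(=O)NCc1ccccc1)C(=O)c1cccc2ccccc12` gives 22800 nM and compound 3 `Cc1cc(C)cc(C(=O)N(CCCCCC(=O)Nc2ccccc2N)CC(=O)NCc2ccccc2)c1` gives 20900 nM as its value. For the measured compounds named here, compound 3 stands within the scatter of both others, so these three numbers set no order among the compounds. Compound 4 `Cc1ccc(CNC(=O)CN(CCCCCC(=O)Nc2ccccc2N)C(=O)c2cc(C)cc(C)c2)cc1` has not yet been measured and differs from compound 3 at one place, with methyl in place of hydrogen on an aromatic carbon so that benzyl becomes 4-methylbenzyl. Going by the values given here, two measured steps bear on this change only indirectly. Benzyl in place of cyclohexyl on an amide-type nitrogen gave a 2.0-fold lower number from compound 1 to compound 3 (0.30 log units; within the scatter) and stayed within the scatter. The exchange of naphthalen-1-yl for 3,5-dimethylphenyl on a carbonyl carbon gave a 1.1-fold lower number from compound 2 to compound 3 (0.04 log units; within the scatter) and also stayed within the scatter. Among the compounds with values here, no measured pair tests a methyl on the benzyl group itself. Since neither of these exchanges left the scatter, one added methyl is not expected to move the number beyond it in either direction. In this assay the expected change is a 1.0-fold lower number from compound 3 to compound 4 (0.02 log units; within the scatter) and it should remain within the scatter. For compound 4 the estimated value is 20000 nM with 11000 nM to 37000 nM as the expected range.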

Compound 4, half-maximal inhibitory concentration: 9800 nM
For compound 4 the middle estimate is 2.0-fold (0.31 log units) above the measured one, and the stated range ends above it.
By their numbers in this assay, from the lowest: compound 4; then compounds 3, 2 and 1 (each within the scatter of the next).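

In this assay, for the compounds shown here, compound 4 supplies the first step that tests the benzyl ring itself and the first to leave the scatter: a single methyl on an aromatic carbon, para to a large group, turning benzyl into 4-methylbenzyl, gives a 2.1-fold lower number from compound 3 to compound 4 (0.33 log units; beyond the scatter). The group on the amide-type nitrogen now also separates two compounds, which the exchange of cyclohexyl for benzyl had not done, since 4-methylbenzyl in place of cyclohexyl gives a 4.3-fold lower number from compound 1 to compound 4 (0.63 log units; beyond the scatter), a modest step but one beyond the scatter. Nothing available here accounts for the effect of this added methyl.

It remains open whether the step depends on this particular carbon of the ring, or on methyl as such, since the compounds shown offer no comparison with a methyl elsewhere on the ring, or with a chlorine, a methoxy group or an ethyl group at the same place. Also open, as far as these compounds go, is whether the methyl would give a similar step with naphthalen-1-yl on the carbonyl carbon in place of 3,5-dimethylphenyl.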